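Amide headgroup swap on a second core variant

This account rests on a few compounds, and the source may have more. Where it says the series, first, only, none or still open, it means among the compounds named here.

Three compounds of the series are measured in a functional assay on A549 cells (Homo sapiens) for antiproliferative activity, read by MTT assay, with a stated time of 72 h; on this read-out lower numbers stand for stronger inhibition and higher numbers for weaker inhibition. Compound 1 `COc1cc(N(C)C)c(NC(=O)c2ccncc2OC)cc1Nc1nccc(-c2cn(C)c3ccccc23)n1` gives 3030 nM. Compound 2 `COc1cc(N(C)C)c(NC(=O)c2ccncn2)cc1Nc1nccc(-c2cn(C)c3ccccc23)n1` differs from compound 1 only by pyrimidin-4-yl in place of 3-methoxypyridin-4-yl on a carbonyl carbon; in this assay compound 2 gives 5160 nM. The step is a 1.7-fold higher number from compound 1 to compound 2 (0.23 log units; within the scatter). Compound 3 `COc1cc(N(C)CCN(C)C)c(NC(=O)c2ccncc2OC)cc1Nc1nccc(-c2cn(CCCO)c3ccccc23)n1` carries a different core; the difference between the core of compound 1 and the core of compound 3 is not broken down here. In this assay compound 3 gives 2390 nM. Compared with compound 1 the two numbers of compound 3 and compound 1 are within the scatter, while the number of compound 2 lies beyond it.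

Compound 4 `COc1cc(N(C)CCN(C)C)c(NC(=O)c2ccncn2)cc1Nc1nccc(-c2cn(CCCO)c3ccccc23)n1` is not yet measured. It differs from compound 3 by pyrimidin-4-yl in place of 3-methoxypyridin-4-yl on a carbonyl carbon, the same change that separates compound 2 from compound 1, made at the same place and with the same neighbours; only the core differs, and that difference is not broken down here. Among the compounds with values here, with one precedent and no evidence that the cores respond differently, the single measured step is taken as the guide. The expected step is a 1.7-fold higher number from compound 3 to compound 4 (0.22 log units; within the scatter), resting on the measured 1.7-fold higher number from compound 1 to compound 2 (0.23 log units; within the scatter). Because that step was a 1.7-fold higher number from compound 1 to compound 2 (0.23 log units; within the scatter), a modest weakening from compound 3 is expected rather than a large one, with the range kept wide to cover the possibility that the second core does not follow.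

Compound 4 is expected at 4000 nM in this assay, with a range from 2300 nM to 7500 nM.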

Compound 4, half-maximal inhibitory concentration: 2660 nM
Estimate against measurement, compound 4: 1.5-fold (0.18 log units) above; the measured number falls inside the stated range.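

In this assay, pyrimidin-4-yl in place of 3-methoxypyridin-4-yl on the carbonyl carbon gives a 1.1-fold higher number from compound 3 to compound 4 (0.05 log units; within the scatter), and the two measured steps for this change do not differ: the same change on two cores in this assay, a 1.7-fold higher number (0.23 log units; within the scatter) from compound 1 to compound 2 and a 1.1-fold higher number (0.05 log units; within the scatter) from compound 3 to compound 4, 1.5-fold (0.18 log units) apart, within the scatter of two such steps. Within these two pairs, the change therefore carries from the core of compound 1 to the core of compound 3 with no detectable difference, and on neither core does it move the number beyond the scatter. This does not show that the two cores respond alike in general, since two small steps from two pairs could not reveal a modest difference between cores, and the pairs say nothing about a change with a larger effect; the difference between the cores is also not broken down, so no single part of it can be tied to the outcome.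

Open, from the compounds shown here alone, is whether another group on the carbonyl carbon, such as phenyl or unsubstituted pyridin-4-yl, would move the number beyond the scatter on either core. Also open, going by these compounds, is whether a core carrying a morpholine or a piperazine would take the same change in the same way.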